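From 3-chlorophenyl to 4-chlorophenyl in the series

The compounds below may be only part of what the source reports. "The series", "measured", "known", "first", "only" and "open" are said of these compounds alone.

In a functional assay on cells (Tumor Cell line, Homo sapiens) for cytotoxicity (a higher number here means a weaker inhibitor, a lower number a stronger inhibitor), compound 1 (`CN(C)Cc1cc(C(=O)/C=C/c2ccccc2)cc(CN(C)C)c1O`) gives 21900 nM and compound 2 (`CN(C)Cc1cc(C(=O)/C=C/c2cccc(Cl)c2)cc(CN(C)C)c1O`) gives 4680 nM. Going by the values given here, compound 2 therefore holds the lower of the two numbers so far. Compound 3 (`CN(C)Cc1cc(C(=O)/C=C/c2ccc(Cl)cc2)cc(CN(C)C)c1O`) differs from compound 2 as follows: 4-chlorophenyl in place of 3-chlorophenyl on a double-bonded chain carbon bound to a double-bonded chain carbon. That is 4-chlorophenyl in place of 3-chlorophenyl on a double-bonded chain carbon bound to a double-bonded chain carbon. Among the compounds with values here, the only measured step with a bearing on this is a 4.7-fold lower number from compound 1 to compound 2 (0.67 log units; beyond the scatter), a modest change beyond the scatter for chloro in place of hydrogen on an aromatic carbon. Within the data shown here, compound 3 keeps the chlorine, and no measured pair shows what moving it does, so the expectation is loose. The expected step is a 1.1-fold higher number from compound 2 to compound 3 (0.03 log units; within the scatter), not beyond the scatter, with its direction open. For compound 3 the estimated value in this assay is 5000 nM, with an expected range of 2200 nM to 12000 nM.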

Compound 3, half-maximal inhibitory concentration: 10000 nM
Beside the measured number, compound 3's estimate is 2.0-fold (0.30 log units) below it, and the stated range covers the measured number.
By their numbers in this assay, from the lowest: compound 2; then compound 3; then compound 1.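

In this assay, moving the chlorine gives a 2.1-fold higher number from compound 2 to compound 3 (0.33 log units; beyond the scatter), so with the same atoms present, 3-chlorophenyl and 4-chlorophenyl on this double-bonded chain carbon are not interchangeable. Chloro in place of hydrogen still lowers the number when the group is 4-chlorophenyl, with a 2.2-fold lower number from compound 1 to compound 3 (0.34 log units; beyond the scatter), so both chlorinated compounds sit below the plain phenyl compound, and the order among the three is compound 2, compound 3, compound 1. Nothing available explains why the place of the chlorine changes the number.

As far as these compounds go, with only chlorine on this ring, it remains open whether the order of the two places is specific to that atom or also holds for a bromo or a methoxy group. From the compounds shown here alone, whether a carboxylic acid at either place would keep or lose the lower number also stays unknown.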